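The source may report more compounds than this note shows. Statements on the series, on what has been measured and on what is new or still open speak of the compounds shown alone.

Measured so far:
compound 1 `Brc1cn2ccnc2c(-c2ccc3ncn(C4CCCCC4)c3c2)n1` gives 13.1% in a functional assay on HCT-15 cells (Homo sapiens) for inhibition, read by sulforhodamine B assay, with a stated time of 48 h, tested at 10 uM; on this read-out higher numbers stand for more inhibition at the one concentration tested (going by the name of the read-out) and lower numbers for less inhibition
compound 2 `Fc1ccc(-c2cn3ccnc3c(-c3ccc4ncn(C5CCCCC5)c4c3)n2)cc1` gives 7.59% in this assay

Compound 2 holds the lower of the two numbers, with compound 1 nearest; the step of a number 5.5 percentage points lower from compound 1 to compound 2 (within the scatter) lies within the scatter, so the two compounds are not separated. Compound 3 `COc1ccccc1-c1cn2ccnc2c(-c2ccc3ncn(C4CCCCC4)c3c2)n1` differs from compound 2 by 2-methoxyphenyl in place of 4-fluorophenyl on an aromatic carbon. For the measured compounds named here, no measured step swaps one aryl group for another; the only step known is the one above, which was within the scatter. Both measured numbers sit low, so no step beyond the scatter is expected here. Compound 3 is estimated at 10% (range 0% to 22%), an expected step of a number 2.4 percentage points higher from compound 2 to compound 3 (within the scatter).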

Compound 3, a percentage reported as inhibition, at one concentration (the size of the read-out at that concentration, not a potency): 33.6%
Beside the measured number, compound 3's estimate is 23.6 percentage points below it; the whole stated range lies below it.
By their numbers in this assay, from the lowest: compounds 2 and 1 (each within the scatter of the next); then compound 3.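

In this assay this position proves sensitive to the group it carries: 2-methoxyphenyl in place of 4-fluorophenyl gives a number 26 percentage points higher from compound 2 to compound 3 (beyond the scatter) and 2-methoxyphenyl in place of bromo gives a number 20.5 percentage points higher from compound 1 to compound 3 (beyond the scatter) while bromo and 4-fluorophenyl stayed within the scatter of each other. One aryl group therefore cannot simply stand in for another here, although both steps are modest. No evidence at hand accounts for the rise. Still open, from the compounds shown here alone, is whether the rise follows the methoxy group itself or its place on the phenyl ring, and how an amine or a carboxylic acid at this position would read.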